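Swapping benzoyloxy for imidazolyl: an expected drop in lipophilicity

A few compounds are considered here, and "the series" means these few. Any claim that something is new, unique, unknown or untested is made for them only; others in the source may bear on it.

Compound 3 `O=C(OC[C@H]1CN(c2ccc(-n3cc(-c4ccccn4)cn3)c(F)c2)C(=O)O1)c1ccccc1` gives 4.21 in a physicochemical assay for lipophilicity, read by HPLC, measured as octanol-water partition (a higher number here means a more lipophilic compound, a lower number a more polar compound), the highest of the three measured values. Compound 1 `O=C1O[C@@H](CN2CCC(O)CC2)CN1c1ccc(-n2cc(-c3ccccn3)cn2)c(F)c1` gives 1.63, and compound 2 `O=C1CSC(=O)N1C[C@H]1CN(c2ccc(-n3cc(-c4ccccn4)cn3)c(F)c2)C(=O)O1` gives 2.18. Compound 4 `O=C1O[C@@H](Cn2ccnc2)CN1c1ccc(-n2cc(-c3ccccn3)cn2)c(F)c1` differs from compound 3 by 1H-imidazol-1-yl in place of benzoyloxy on a saturated chain carbon bound to a saturated ring carbon. Going by the values given here, two measured steps bear on this: a number 2.58 log units higher from compound 1 to compound 3 (beyond the scatter) and a number 2.03 log units higher from compound 2 to compound 3 (beyond the scatter). Both show that exchanging the benzoyloxy group for a nitrogen-containing group on that chain carbon moves this assay by a large amount, and read backwards both point downward. For compound 4 a large downward step, a number 2.21 log units lower from compound 3 to compound 4 (beyond the scatter), is therefore expected. Compound 4 is estimated at 2, with a likely range from 1.4 to 2.6.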

Compound 4, partition coefficient: 1.73
Beside the measured number, compound 4's estimate is 0.27 log units above it; low and high end bracket the measured number.
By their numbers in this assay, from the lowest: compounds 1 and 4 (each within the scatter of the next); then compound 2; then compound 3.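

In this assay the move to 1H-imidazol-1-yl on this chain carbon gives another large step down from benzoyloxy (a number 2.48 log units lower from compound 3 to compound 4 (beyond the scatter)), so benzoyloxy now stands apart from all three other groups. The new group also separates from 2,4-dioxo-1,3-thiazolidin-3-yl (a number 0.45 log units lower from compound 2 to compound 4 (beyond the scatter)) but cannot be told apart from 4-hydroxypiperidin-1-yl (a number 0.10 log units higher from compound 1 to compound 4 (within the scatter)). No measurement shown explains these steps. Going by these compounds, whether an open-chain amine or a carboxylic acid at this place would sit with compound 4 or nearer compound 3 remains open.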